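The source may report more compounds than this note shows. Statements on the series, on what has been measured and on what is new or still open speak of the compounds shown alone.

Measured so far:

compound 1 `Cn1c(-c2cccc(Cl)c2)cnc1NC(=O)c1ccc(F)cc1` — > 50000 nM
compound 2 `Cn1c(-c2ccc(C#N)cc2)cnc1NC(=O)c1ncc[nH]1` — > 100000 nM
compound 3 `Cn1c(-c2cccc([N+](=O)[O-])c2)cnc1NC(=O)c1ccc(F)cc1` — > 50000 nM

In a toxicity assay on THP-1 cells (Homo sapiens) for inhibition (on this read-out higher numbers stand for lower toxicity in this test and lower numbers for higher toxicity in this test), compound 1 gives > 50000 nM, which is a limit of the assay and not a measured number. Compound 3 gives > 50000 nM, likewise a limit. Compound 2 gives > 100000 nM, again a limit. Two of the three values rest at the limit of > 50000 nM in this assay, at which 2 of the 3 values shown sit, and one at the limit of > 100000 nM in this assay, at which 1 of the 3 values shown sits, so none of them pins down an actual toxicity. For the measured compounds named here, the one single-change step among the measured compounds, a step that the two limits leave unreadable from compound 1 to compound 3, therefore has no readable size.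

Compound 4 `Cn1c(-c2ccccc2F)cnc1NC(=O)c1ccc(F)cc1` is the next compound to be tested. It differs from compound 1 by 2-fluorophenyl in place of 3-chlorophenyl on an aromatic carbon. Going by the values given here, no measured step touches this particular change, and the values at hand only show that every compound so far stayed beyond the assay ceiling. No step beyond the usual scatter is therefore expected in either direction. Compound 4 is expected to give about 60000 nM in this assay, within a range from 20000 nM to 150000 nM. That estimate means a step that the limit leaves unreadable from compound 1 to compound 4, expected to be flat.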

Compound 4, half-maximal cytotoxic concentration: > 100000 nM
Compound 4: no number, only a limit; the forecaster's own chance of this, stated with the estimate: 85%; middle value at least 1.6-fold (0.22 log units) from the limit.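

In this assay compound 4 gives > 100000 nM, which is a limit of the assay and not a number. Compound 1 also sits at a limit, and the step between compound 1 and compound 4 cannot be read. The compounds shown leave open at what concentration any of them becomes toxic to these cells.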